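This account rests on a few compounds, and the source may have more. Where it says the series, first, only, none or still open, it means among the compounds named here.

The compounds measured so far:
compound 1, `COc1cccc(NC2=CC(=O)c3c(nc4n3[C@H]3OC[C@@H](O)[C@H]3OC4)C2=O)c1`, gives 3830 nM.
Compound 2, `O=C1C(NC2CCCCC2)=CC(=O)c2c1nc1n2[C@H]2OC[C@@H](O)[C@H]2OC1`, reaches only a limit of the assay, > 16000 nM.
Compound 3, `O=C1C(Nc2ccccc2)=CC(=O)c2c1nc1n2[C@H]2OC[C@@H](O)[C@H]2OC1`, likewise reaches only a limit of the assay, > 4000 nM.

All three were tested in a functional assay on MCF7 cells (Homo sapiens) for inhibition, read by sulforhodamine B assay; on this read-out lower numbers stand for stronger inhibition and higher numbers for weaker inhibition. For compound 3 only a limit is known, not a number, so its standing can be read only through its neighbours. Hydrogen in place of methoxy on an aromatic carbon gives an at least 1.0-fold higher number from compound 1 to compound 3 (0.01 log units; that floor lies within the scatter). Cyclohexyl in place of 3-methoxyphenyl on an amine nitrogen gives an at least 4.1-fold higher number from compound 1 to compound 2 (0.62 log units; beyond the scatter), while a step that the two limits leave unreadable from compound 2 to compound 3.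

Compound 4, `CCCN(CCC)C1=CC(=O)c2c(nc3n2[C@H]2OC[C@@H](O)[C@H]2OC3)C1=O`, differs from compound 3 by dipropylamino in place of anilino on a double-bonded ring carbon. The step that bears on it is the one in which the aromatic ring on the amine nitrogen was lost, an at least 4.1-fold higher number from compound 1 to compound 2 (0.62 log units; beyond the scatter); compound 4 loses that ring too and carries no hydrogen-bond donor. A higher number, meaning weaker inhibition, is therefore expected, at least modest in size, and most likely the assay will again report only a limit. The step from compound 3 is expected as a step that the limit leaves unreadable from compound 3 to compound 4. Compound 4 is expected to give about 12000 nM, within 4000 nM to 40000 nM.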

Compound 4, half-maximal inhibitory concentration: > 16000 nM
Compound 4 gave a limit, no number; the forecaster's own chance of this, stated with the estimate: 70%; middle value at least 1.3-fold (0.12 log units) away from the limit.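

In this assay, dipropylamino in place of (3-methoxyphenyl)amino on the double-bonded ring carbon gives an at least 4.1-fold higher number from compound 1 to compound 4 (0.62 log units; beyond the scatter). So a second amine without an aromatic ring on its nitrogen, this time an open-chain one with no hydrogen-bond donor, also falls short of compound 1, and it does so just as compound 2 does, with both compounds stopping at the same limit of the assay rather than at a number. The steps from compound 2 and from compound 3 to compound 4 cannot be read, since every value involved is only a limit, and compound 3, which keeps its aromatic ring, therefore neither supports nor opposes the link between that ring and activity: the limit of > 16000 nM in this assay, at which 2 of the 4 values shown sit.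

As far as these compounds go, with compound 2 and compound 4 both at a limit, it remains open whether the hydrogen-bond donor on the nitrogen counts for anything once the aromatic ring is gone. From the compounds shown here alone, it is also open whether the methoxy group matters at all, and how the core would respond to a benzylamino group, a pyridine ring on the nitrogen, or a smaller amine such as dimethylamino.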